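Benzyl substituent variation in the shared core series

This account rests on a few compounds, and the source may have more. Where it says the series, first, only, none or still open, it means among the compounds named here.

Compound 1 `O=C1/C(=C\c2ccccc2)c2c(ncn2COCc2ccccc2)CCN1Cc1ccccc1`: 13900 nM
Compound 2 `Cc1cc(C)cc(CN2CCc3ncn(COCc4ccccc4)c3/C(=C/c3ccccc3)C2=O)c1`: 40900 nM

In a functional assay on HepG2 cells (Homo sapiens) for inhibition, read by MTT assay, with a stated time of 72 h (a higher number here means a weaker inhibitor, a lower number a stronger inhibitor), compound 1 gives 13900 nM, while compound 2 gives 40900 nM, the higher of the two numbers. Among the measured compounds shown here, the single measured step between them is a 2.9-fold higher number from compound 1 to compound 2 (0.47 log units; beyond the scatter).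

Compound 3 `O=C1/C(=C\c2ccccc2)c2c(ncn2COCc2ccccc2)CCN1Cc1ccc(Cl)cc1` differs from compound 2 in one place: 4-chlorophenyl in place of 3,5-dimethylphenyl on a saturated chain carbon bound to an amide-type nitrogen in a ring. For the measured compounds named here, no measured step touches 4-chlorophenyl, so the only guide is a 2.9-fold higher number from compound 1 to compound 2 (0.47 log units; beyond the scatter). In that step the 3,5-dimethylphenyl enters at the same place where it now leaves. A modest drop back toward the number of compound 1 is expected, a 2.3-fold lower number from compound 2 to compound 3 (0.36 log units; beyond the scatter), rather than a step beyond it. Compound 3 is therefore estimated at 18000 nM, with a range of 7000 nM to 45000 nM.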

Compound 3, half-maximal inhibitory concentration: 47900 nM
For compound 3 the middle estimate is 2.7-fold (0.43 log units) below the measured one; measured number outside the range, above it.
By their numbers in this assay, from the lowest: compound 1; then compounds 2 and 3 (each within the scatter of the next).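

In this assay, 4-chlorophenyl and 3,5-dimethylphenyl on a saturated chain carbon bound to an amide-type nitrogen in a ring cannot be told apart (a 1.2-fold higher number from compound 2 to compound 3 (0.07 log units; within the scatter)). Chloro in place of hydrogen on an aromatic carbon also moves the number up (a 3.4-fold higher number from compound 1 to compound 3 (0.54 log units; beyond the scatter)), so both substituted phenyl groups shown give higher numbers than the unsubstituted phenyl of compound 1. No evidence bears on what lies behind these steps.

Still open, as far as these compounds go, is whether a methoxy group, a carboxylic acid or an amine on the phenyl ring would give a number at or below that of compound 1. From the compounds shown here alone, the effect of a longer chain at this place is also open.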